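Cladinose removal in a macrolide series: solubility notes

The compounds below may be only part of what the source reports. "The series", "measured", "known", "first", "only" and "open" are said of these compounds alone.

Compound 1 `CC[C@H]1OC(=O)[C@H](C)[C@@H](O[C@H]2C[C@@](C)(OC)[C@@H](O)[C@H](C)O2)[C@H](C)[C@@H](O[C@@H]2O[C@H](C)C[C@H](N(C)C)[C@H]2OCCCNC(=O)CNc2ccnc3ccccc23)[C@](C)(O)C[C@@H](C)CN(C)[C@H](C)[C@@H](O)[C@]1(C)O` and compound 2 `CC[C@H]1OC(=O)[C@H](C)[C@@H](O)[C@H](C)[C@@H](O[C@@H]2O[C@H](C)C[C@H](N(C)C)[C@H]2OCCCNC(=O)CNc2ccnc3ccccc23)[C@](C)(O)C[C@@H](C)CN(C)[C@H](C)[C@@H](O)[C@]1(C)O` are measured in a physicochemical assay for solubility, at pH 4; on this read-out lower numbers stand for lower solubility and higher numbers for higher solubility. In this assay compound 1 sits at a limit, > 10000 ug/mL, not a number. Compound 2 likewise reaches only a limit, > 10000 ug/mL. The change between them is hydrogen in place of 5-hydroxy-4-methoxy-4,6-dimethyloxan-2-yl on an oxygen on a saturated carbon, and its step is a step that the two limits leave unreadable from compound 1 to compound 2; the two limits leave its size unreadable, as the limit of > 10000 ug/mL in this assay, at which 3 of the 3 values shown sit, notes.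

Compound 3 `CC[C@H]1OC(=O)[C@H](C)[C@@H](O[C@H]2C[C@@](C)(OC)[C@@H](O)[C@H](C)O2)[C@H](C)[C@@H](O[C@@H]2O[C@H](C)C[C@H](N(C)C)[C@H]2OCCCN(C)Cc2cnc3ccccc3c2)[C@](C)(O)C[C@@H](C)CN(C)[C@H](C)[C@@H](O)[C@]1(C)O` carries a different core; how it differs from the core of compound 1 is not broken down here. In this assay compound 3 also gives only a limit, > 10000 ug/mL.

Compound 4 `CC[C@H]1OC(=O)[C@H](C)[C@@H](O)[C@H](C)[C@@H](O[C@@H]2O[C@H](C)C[C@H](N(C)C)[C@H]2OCCCN(C)Cc2cnc3ccccc3c2)[C@](C)(O)C[C@@H](C)CN(C)[C@H](C)[C@@H](O)[C@]1(C)O` is not yet measured. It differs from compound 3 by hydrogen in place of 5-hydroxy-4-methoxy-4,6-dimethyloxan-2-yl on an oxygen on a saturated carbon, the same change as from compound 1 to compound 2, at the same place. Since compound 3 sits at > 10000 ug/mL and the earlier step is a step that the two limits leave unreadable from compound 1 to compound 2, the step that the limit leaves unreadable from compound 3 to compound 4 is expected to be unreadable in the same way, and compound 4 is estimated at 15000 ug/mL, most likely again reported as a limit.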

Compound 4, solubility: > 10000 ug/mL
Compound 4: no number, only a limit; the forecaster's own chance of this, stated with the estimate: 90%; the middle value does not contradict the limit.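

Compound 3 and compound 4 both give only a limit in this assay, so no step can be read between them: the limit of > 10000 ug/mL in this assay, at which 4 of the 4 values shown sit.

The compounds shown leave open whether hydrogen in place of 5-hydroxy-4-methoxy-4,6-dimethyloxan-2-yl changes the read-out of this assay at all.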